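Series notes: from compound 2 to compound 4

The compounds below may be only part of what the source reports. "The series", "measured", "known", "first", "only" and "open" are said of these compounds alone.

Compound 1 `CC1=CC[C@H](C(C)(C)NC(=S)NN)CC1` is the parent of the series. In a functional assay on MCF7 cells (Homo sapiens) for inhibition, read by sulforhodamine B assay, with a stated time of 48 h (a higher number here means a weaker inhibitor of growth, a lower number a stronger inhibitor of growth), compound 1 gives 46700 nM. Compound 2 `CC1=CC[C@H](C(C)(C)NC(=S)N/N=C/c2ccc(O)cc2)CC1` adds a 4-hydroxyphenyl on the carbon double-bonded to nitrogen. In this assay compound 2 reaches only a limit of the assay, > 100000 nM. Compound 3 `CC1=CC[C@H](C(C)(C)NC(=S)N/N=C/c2ccc(N(C)C)cc2)CC1` likewise returns only a limit in this assay, > 100000 nM. The step that the two limits leave unreadable from compound 2 to compound 3 is accordingly not readable in size or direction. Compound 2 thus stands at the limit, with compound 3 at the same limit, and only compound 1 gives a number.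

Compound 4 `CC1=CC[C@H](C(C)(C)NC(=S)N/N=C/c2ccccc2Cl)CC1` is not yet measured. The change from compound 2 is 2-chlorophenyl in place of 4-hydroxyphenyl on a carbon with a double bond to nitrogen. Going by the values given here, no measured step bears directly on this change; the one step among the measured compounds is hidden by the limit of > 100000 nM in this assay, at which 2 of the 3 values shown sit. Both measured compounds carrying a substituted phenyl at that position sit at the limit. Compound 4 is therefore expected to remain near that limit, with the step of an at least 1.1-fold lower number from compound 2 to compound 4 (0.04 log units; that floor lies within the scatter) expected to stay within the scatter. The estimate for compound 4 in this assay is 90000 nM, with a range from 35000 nM to 200000 nM.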

Compound 4, concentration for total growth inhibition: 98300 nM
For compound 4 the middle estimate is 1.1-fold (0.04 log units) below the measured one; low and high end bracket the measured number.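

With 2-chlorophenyl on the carbon with a double bond to nitrogen, compound 4 gives 98300 nM in this assay, a number rather than a limit. Against the 4-hydroxyphenyl of compound 2 the comparison holds only as a floor, an at least 1.0-fold lower number from compound 2 to compound 4 (0.00 log units; that floor lies within the scatter), so no change in growth inhibition can be claimed for this swap, even though the entering group has no hydrogen-bond donor or acceptor and the leaving group has them. The reading remains one-sided: the limit of > 100000 nM in this assay, at which 2 of the 4 values shown sit.

Still open, going by these compounds, is whether a phenyl bearing a carboxylic acid or a primary amine, or a longer alkyl chain in place of the aromatic ring at this carbon, would give a number clearly lower than that of compound 4. Also open, on these data alone, is whether 4-chlorophenyl would read the same as 2-chlorophenyl.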